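Swapping the group on the sulfonyl sulfur of compound 2

A few compounds are considered here, and "the series" means these few. Any claim that something is new, unique, unknown or untested is made for them only; others in the source may bear on it.

Compound 1 `O=S(=O)(CCO)c1cccc(-c2ccc3nccc(-c4ccncc4)c3n2)c1` gives 52% in an ADME assay on microsomes from liver (Mus musculus) for metabolic stability, read by LC-MS, using NADPH, with a stated time of 30 min, tested at 0.1 uM (on this read-out lower numbers stand for a less stable compound and higher numbers for a more stable compound), as its result.
Compound 2 `O=S(=O)(c1cccc(-c2ccc3nccc(-c4ccncc4)c3n2)c1)N1CC[C@H](O)C1` gives 12% in this assay as its result.

Of these two compounds, compound 2 holds the lower number, and the gap to compound 1 lies beyond the scatter. Compound 3 `C[C@@H]1CN(S(=O)(=O)c2cccc(-c3ccc4nccc(-c5ccncc5)c4n3)c2)C[C@H](C)N1` has not yet been measured. It differs from compound 2 in one place, with 3,5-dimethylpiperazin-1-yl in place of 3-hydroxypyrrolidin-1-yl on a sulfonyl sulfur is the counted difference.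

Among the measured compounds shown here, only one measured step bears on this change. That step is a number 40 percentage points lower from compound 1 to compound 2 (beyond the scatter) and it falls at the same sulfonyl sulfur, so a change there can be large. It does not involve 3,5-dimethylpiperazin-1-yl, however, and so gives neither the size nor the direction of the coming step. No step beyond the scatter is therefore expected, and the range stays wide. The expected step is a number 6 percentage points higher from compound 2 to compound 3 (within the scatter) as a rough estimate. Compound 3 is expected at 18% with a range of 4% to 42% around that estimate.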

Compound 3, percent of the compound remaining: 33%
For compound 3 the middle estimate is 15 percentage points below the measured one; the measured number falls inside the stated range.
By their numbers in this assay, from the lowest: compound 2; then compound 3; then compound 1.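

In this assay the group on the sulfonyl sulfur now gives a second step beyond the scatter, and it runs the opposite way to the first: 3,5-dimethylpiperazin-1-yl in place of 3-hydroxypyrrolidin-1-yl brings a number 21 percentage points higher from compound 2 to compound 3 (beyond the scatter) on the same core. A ring on the sulfonyl sulfur therefore does not settle the number by itself, as compound 2 and compound 3 stand apart. Even so, 3,5-dimethylpiperazin-1-yl in place of 2-hydroxyethyl brings a number 19 percentage points lower from compound 1 to compound 3 (beyond the scatter) and leaves the 2-hydroxyethyl of compound 1 with the highest number of the three, while nothing given here accounts for these differences.

Going by these compounds, what remains open is which part of the change from 3-hydroxypyrrolidin-1-yl carries the step: the six-membered ring, the second ring nitrogen or the two methyl groups. A plain piperazin-1-yl would separate the methyl groups from the ring, and a morpholin-4-yl or a longer chain such as 3-hydroxypropyl on the sulfonyl sulfur would show how far the number at this position can move.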